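A few compounds are considered here, and "the series" means these few. Any claim that something is new, unique, unknown or untested is made for them only; others in the source may bear on it.

For the measured compounds named here, compound 1 `Oc1c(Cl)cc(Cl)c2ccc(/C=C/c3ccccc3Cl)nc12` heads the two measured members in a physicochemical assay for lipophilicity, read by HPLC; a higher number here means a more lipophilic compound, a lower number a more polar compound: compound 1 gives 6.02. Going by the values given here, the only other measured member, compound 2 `CCOc1ccc(/C=C/c2ccc3cccc(O)c3n2)cc1`, gives 4.55 in this assay, a value that lies well below compound 1 and beyond the scatter of repeated measurements. Among the compounds with values here, no pair of measured compounds differs in a single place, so no isolated single-change step can be read from the measured data.

Compound 3 `Oc1ccccc1/C=C/c1ccc2c(Cl)cc(Cl)c(O)c2n1` has not yet been measured in this assay. It differs from compound 1 by hydroxy in place of chloro on an aromatic carbon. This change is expected to lower the number in this assay, and the step from compound 1 to compound 3 is estimated at a number 1.02 log units lower from compound 1 to compound 3 (beyond the scatter), a step beyond the usual scatter. For compound 3 the expected value in this assay is 5, with a range from 4.5 to 5.5.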

Compound 3, partition coefficient: 5.07
Estimate against measurement, compound 3: 0.07 log units below, and the stated range covers the measured number.
By their numbers in this assay, from the lowest: compound 2; then compound 3; then compound 1.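

For the compounds shown here, this is the first single-change step. On an aromatic carbon of a six-membered aromatic ring of carbon only, ortho to a large group, the exchange of 2-chlorophenyl for 2-hydroxyphenyl gives a number 0.95 log units lower from compound 1 to compound 3 (beyond the scatter) in this assay, so this position registers a change of one heavy atom beyond the scatter, with the rest of the core of compound 1 held constant. Nothing available accounts for the size of this step.

A single step at a single place cannot show whether hydroxy in place of chloro would give a similar step elsewhere on the core. Going by these compounds, how an amine, a methoxy group or a carboxylic acid at this position would compare with hydroxy and chloro also remains open.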